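A few compounds are considered here, and "the series" means these few. Any claim that something is new, unique, unknown or untested is made for them only; others in the source may bear on it.

Measured so far:
- Compound 1 `CCn1c(CNc2ccccc2)nnc1SCC(=O)Nc1ccc(C(=O)OC)cc1`: in an assay on isolated protein for inhibition of long-chain fatty acid transport protein 1 (Homo sapiens) (on this read-out higher numbers stand for weaker inhibition and lower numbers for stronger inhibition), compound 1 gives 540 nM
- Compound 2 `CCn1c(CNc2ccccc2)nnc1SCC(=O)Nc1ccc(C(C)=O)cc1`: for compound 2 this assay reports only the limit > 1000 nM, not a number
- Compound 3 `CCn1c(CNc2ccccc2)nnc1SCc1nc2cc(OC(F)(F)F)ccc2o1`: in this assay compound 3 gives 100 nM

Compound 2 thus stands at the weak end of what has been measured, and only as a limit, which the limit of > 1000 nM in this assay, at which 1 of the 3 values shown sits, describes. Compound 4 `CCn1c(CNc2ccccc2)nnc1SCC(=O)Nc1ccc(C(=O)OC(C)(C)C)cc1` is not yet measured. It differs from compound 2 in one place: tert-butoxy in place of methyl on a carbonyl carbon. Among the measured compounds shown here, the one measured step that bears on this is an at least 1.8-fold higher number from compound 1 to compound 2 (0.26 log units; that floor lies within the scatter), where methyl replaced methoxy on the same carbonyl carbon and the number rose, though only to a limit. Going to compound 4 brings an alkoxy group back onto that carbonyl carbon, now larger than in compound 1. The step to compound 4 is therefore expected to run back toward the number of compound 1, giving an estimated at least 1.4-fold lower number from compound 2 to compound 4 (0.15 log units; that floor lies within the scatter) in this assay. For compound 4 a value of about 700 nM is expected, between 250 nM and 2500 nM.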

Compound 4, half-maximal inhibitory concentration: > 1000 nM
Compound 4: a limit, no number (the forecaster's own chance of this, stated with the estimate: 35%); at least 1.4-fold (0.15 log units) between middle value and limit.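

In this assay compound 4 gives > 1000 nM, which is a limit and not a number, so putting an alkoxy group back on this carbonyl carbon, here as tert-butoxy, does not by itself return a readable value. Swapping the group on the oxygen, tert-butyl in place of methyl, gives an at least 1.8-fold higher number from compound 1 to compound 4 (0.26 log units; that floor lies within the scatter), so even this change is not shown to be a real loss of inhibition. The step between compound 2 and compound 4 cannot be read, and compound 1 remains the only compound with a readable value among those changed at this carbonyl carbon: the limit of > 1000 nM in this assay, at which 2 of the 4 values shown sit.

As far as these compounds go, how compound 2 and compound 4 truly compare stays unknown. Also open, from the compounds shown here alone, is whether a carboxylic acid, a primary amide or an ethoxy group on this carbonyl carbon would give a readable number.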